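This account rests on a few compounds, and the source may have more. Where it says the series, first, only, none or still open, it means among the compounds named here.

Of the compounds shown here, three built on a shared amide core have been tested in a functional assay on MDBK cells (Bos taurus) for cytotoxicity; on this read-out lower numbers stand for higher toxicity in this test and higher numbers for lower toxicity in this test. Compound 1 `CCC(C)N1CCC(NC(=O)c2cc(C)ccc2O)CC1` gives 100 ug/mL. Compound 3 `C[C@@H]1CCC[C@H](C)N1CCCCNC(=O)c1cc(Cl)ccc1O` gives 100 ug/mL, which is level with compound 1 at the digits shown, so the two lie within the usual scatter of each other. Compound 2 `Cc1ccc(O)c(C(=O)NCCCN(C(C)C)C(C)C)c1` reaches only a limit of this assay, > 100 ug/mL, the limit described by the limit of > 100 ug/mL in this assay, at which 1 of the 3 values shown sits; it is a boundary of the measurement, not a number.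

Compound 4 `Cc1ccc(O)c(C(=O)NCCCCN2[C@H](C)CCC[C@@H]2C)c1` has not yet been measured. It differs from compound 3 in a single place: methyl in place of chloro on an aromatic carbon. Going by the values given here, no pair of measured compounds isolates exactly this change, so no measured size can be attached to it. Compound 1 also carries methyl rather than chloro on its aromatic ring and gives 100 ug/mL, level with compound 3. On that basis the step from compound 3 to compound 4 in this assay is expected to be no change at the digits printed from compound 3 to compound 4 (within the scatter), none beyond the scatter. Compound 4 is therefore estimated at 100 ug/mL in this assay, within a range from 50 ug/mL to 200 ug/mL, with a real chance that only a limit is reported.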

Compound 4, half-maximal cytotoxic concentration: > 100 ug/mL
Compound 4 was reported as a limit (the forecaster's own chance of this, stated with the estimate: 50%); the middle value sits exactly at the limit.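

In this assay, compound 3 and compound 4 form the first pair shown that differs in one place only: methyl in place of chloro on an aromatic carbon, para to a hydroxy group and meta to a large group. This pair gives a number no lower from compound 3 to compound 4 (the limit leaves the size open), so at this position, on this side chain, methyl brings no higher toxicity in this test than chloro, although how far the number moves cannot be read. Compound 4 gives > 100 ug/mL in this assay, which is a limit of the assay and not a number, and the top of the range now restricts what the set can separate: the limit of > 100 ug/mL in this assay, at which 2 of the 4 values shown sit.

The compounds shown carry only methyl or chloro at this position, so what a methoxy group, a fluoro group or a nitrile would do there in this assay stays open. Also open is whether the same swap would give the same result on the different side chains of compound 1 and compound 2, since neither has a chloro partner among the compounds shown.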